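Compound 3: 1H-indol-7-yl in place of 3-cyanophenyl

A few compounds are considered here, and "the series" means these few. Any claim that something is new, unique, unknown or untested is made for them only; others in the source may bear on it.

Measured in a physicochemical assay for solubility; a lower number here means a less soluble compound, a higher number a more soluble compound:
Compound 1 `CNC(=O)c1cc(C(=O)NC2CC2)cn(CC2CCCOC2)c1=O`: >= 131 ug/mL, a limit
Compound 2 `CNC(=O)c1cc(C(=O)NC2CC2)cn(Cc2cccc(C#N)c2)c1=O`: >= 148 ug/mL, a limit

Compound 2 stands at the limit of >= 148 ug/mL in this assay, at which 1 of the 2 values shown sits, and this is a limit, not a number. Compound 1 also has only a limit, so neither measured compound gives a number to work from.

The next compound, compound 3 `CNC(=O)c1cc(C(=O)NC2CC2)cn(Cc2cccc3cc[nH]c23)c1=O`, carries 1H-indol-7-yl in place of 3-cyanophenyl on a saturated chain carbon bound to an aromatic nitrogen.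

Among the compounds with values here, the one measured step that bears on this change is a step that the two limits leave unreadable from compound 1 to compound 2. It falls at the same place, but it offers no size to carry over. The expectation in this assay therefore rests on the structural change alone and is weak. A modest fall is expected, although compound 3 could also end up reported as a limit. The expected step, held loosely, is an at least 1.6-fold lower number from compound 2 to compound 3 (0.21 log units; that floor lies within the scatter). For compound 3 the estimated value is 90 ug/mL, with an expected range from 30 ug/mL to 220 ug/mL.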

Compound 3, solubility: >= 144 ug/mL
Compound 3: only a limit was reported; the forecaster's own chance of this, stated with the estimate: 35%; at least 1.6-fold (0.20 log units) between middle value and limit.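

In this assay compound 3 gives >= 144 ug/mL, which is a limit and not a number. Within the data shown here, compound 1 and compound 2 also carry only limits, so no step among compound 1, compound 2 and compound 3 can be read. The compounds shown leave open whether oxan-3-yl, 3-cyanophenyl and 1H-indol-7-yl differ at all in this assay.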